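This account rests on a few compounds, and the source may have more. Where it says the series, first, only, none or still open, it means among the compounds named here.

Compound 1, with the structure `Cc1cnc(Nc2ccc(Cl)cc2)nc1Nc1nc2ccccc2s1`, is the starting point of this step. In a functional assay on MDA-MB-231 cells (Homo sapiens) for antiproliferative activity, read by MTT assay, with a stated time of 48 h (a higher number here means a weaker inhibitor, a lower number a stronger inhibitor), compound 1 gives > 50000 nM, which is a limit of the assay rather than a measured number, so its true value is known only to lie beyond that point; the same limit, (the limit of > 50000 nM in this assay, at which 1 of the 3 values shown sits), is where one of the three values given here sits. Two related compounds were measured as numbers: compound 2 `COc1ccc2nc(Nc3nc(Nc4ccc(S(N)(=O)=O)cc4)ncc3F)sc2c1` gives 26600 nM, and compound 3 `COc1ccc2nc(Nc3nc(Nc4ccc(S(C)(=O)=O)cc4)ncc3F)sc2c1` gives 4740 nM. Among the measured compounds shown here, the one measured step between compounds differing in a single place is a 5.6-fold lower number from compound 2 to compound 3 (0.75 log units; beyond the scatter), a change on a sulfonyl sulfur far from the part that changes here. Compound 4 `Cc1cnc(Nc2cccc(F)c2)nc1Nc1nc2ccccc2s1` differs from compound 1 by 3-fluorophenyl in place of 4-chlorophenyl on a nitrogen on an aromatic ring. For the measured compounds named here, no measured step touches this part of the molecule, so there is nothing to say which way the number should move. Compound 1 already sits at the limit, and compound 4 is therefore expected to sit there as well, with an estimate of 50000 nM, a range of 15000 nM to 150000 nM, meaning an expected step of a number no higher from compound 1 to compound 4 (the limit leaves the size open).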

Compound 4, half-maximal inhibitory concentration: > 50000 nM
Compound 4 ended at the assay's limit; the forecaster's own chance of this, stated with the estimate: 70%; the middle value sits exactly at the limit.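

Among the compounds shown here, compound 1 and compound 4 both sit at a limit rather than at a measured number, so no step between them can be read: the limit of > 50000 nM in this assay, at which 2 of the 4 values shown sit.

The compounds shown leave open how far past that limit each lies, and whether swapping 4-chlorophenyl for 3-fluorophenyl changes the result at all.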